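From phenoxy back to a pyridin-3-yl carbonyl

A few compounds are considered here, and "the series" means these few. Any claim that something is new, unique, unknown or untested is made for them only; others in the source may bear on it.

In a functional assay on HCT-15 cells (Homo sapiens) for antiproliferative activity (on this read-out higher numbers stand for weaker inhibition and lower numbers for stronger inhibition), compound 1 `COc1ccc(S(=O)(=O)Oc2ccccc2NC(=O)c2ccc(F)cc2)cc1` gives 89 nM. Compound 2 `COc1ccc(S(=O)(=O)Oc2ccccc2NC(=O)Oc2ccccc2)cc1` stands only at a limit of the assay, > 10000 nM. Going by the values given here, the one measured step that bears on the next change is large: an at least 110-fold higher number from compound 1 to compound 2 (2.05 log units; beyond the scatter), with phenoxy in place of 4-fluorophenyl on a carbonyl carbon. Compound 3 `COc1ccc(S(=O)(=O)Oc2ccccc2NC(=O)c2cccnc2)cc1` removes that phenoxy: pyridin-3-yl in place of phenoxy on a carbonyl carbon. A large step to a lower number is therefore expected in this assay, with the expected change being an at least 33-fold lower number from compound 2 to compound 3 (1.52 log units; beyond the scatter). For compound 3 the estimated value is 300 nM, with an expected range of 60 nM to 2500 nM.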

Compound 3, half-maximal inhibitory concentration: > 3000 nM
Compound 3: no number, only a limit (the forecaster's own chance of this, stated with the estimate: 12%); middle value at least 10-fold (1.00 log units) away from the limit.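

In this assay compound 3 gives > 3000 nM, which is a limit and not a number. Taking phenoxy off the carbonyl carbon is therefore not enough to recover the activity of compound 1: pyridin-3-yl on that carbon also falls well short of 4-fluorophenyl, with an at least 33-fold higher number from compound 1 to compound 3 (1.52 log units; beyond the scatter). The step between compound 2 and compound 3 cannot be read, as both values are limits.

From the compounds shown here alone, how phenoxy and pyridin-3-yl rank on this carbon stays open. So does whether a plain phenyl or a cyclohexyl on the same carbonyl carbon would stay close to compound 1.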